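Indole benzo-ring swap in a weakly active ester series

The source may report more compounds than this note shows. Statements on the series, on what has been measured and on what is new or still open speak of the compounds shown alone.

Of the compounds shown here, two of the shared core have been measured. Compound 1 `COC(=O)[C@@]1(C)CCC=C2[C@@H]1CC[C@@H](C)[C@]2(C)Cc1c[nH]c2ccc(C)cc12` gives 22000 nM in a functional assay on WiDr cells (Homo sapiens) for inhibition, read by sulforhodamine B assay, with a stated time of 48 h; on this read-out higher numbers stand for weaker inhibition of growth and lower numbers for stronger inhibition of growth. Compound 2 `COC(=O)[C@@]1(C)CCC=C2[C@@H]1CC[C@@H](C)[C@]2(C)Cc1c[nH]c2c(C)cccc12` gives 26000 nM in this assay; its number and that of compound 1 sit within the scatter of each other, so the two cannot be ranked. Compound 3 `COC(=O)[C@@]1(C)CCC=C2[C@@H]1CC[C@@H](C)[C@]2(C)Cc1c[nH]c2c(Cl)cccc12` is not yet measured; it differs from compound 2 by chloro in place of methyl on an aromatic carbon. For the measured compounds named here, with no measured step of this kind to lean on, compound 3 is expected to stay close to compound 2, with a step of a 1.3-fold lower number from compound 2 to compound 3 (0.11 log units; within the scatter) that need not exceed the scatter. The estimate for compound 3 in this assay is 20000 nM, within 8000 nM to 50000 nM.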

Compound 3, concentration for 50% growth inhibition: 31000 nM
The estimate for compound 3 lay 1.6-fold (0.19 log units) below the measured number; measured number inside the range.
By their numbers in this assay, from the lowest: compounds 1, 2 and 3 (each within the scatter of the next).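

On the aromatic carbon ortho to a fused ring, chloro in place of methyl gives a 1.2-fold higher number from compound 2 to compound 3 (0.08 log units; within the scatter) in this assay, the first one-place step available in this series. Within this assay, methyl and chloro at this position cannot be told apart, so this exchange offers no handle on growth inhibition. No measurement bearing on the reason for this result is at hand.

As far as these compounds go, whether an amine, a carboxylic acid or a longer chain on this aromatic carbon would give a step beyond the scatter remains open. So does the effect of exchanging the methyl ester of the shared core for a carboxylic acid.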